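The compounds below may be only part of what the source reports. "The series", "measured", "known", "first", "only" and "open" are said of these compounds alone.

In a functional assay on DU-145 cells (Homo sapiens) for cytotoxicity, read by MTT assay, with a stated time of 24 h (a higher number here means a weaker inhibitor, a lower number a stronger inhibitor), compound 3 (`CCCCCCCC/C=C\CCCCCCCC(=O)Nc1nnc(S[C@@H]2O[C@H](CO)[C@H](O)[C@H](O)[C@H]2O)s1`) gives "not active" (no number reported) with no single number attached, and compound 2 (`CCCCCCCC(=O)Nc1nnc(S[C@@H]2O[C@H](CO)[C@H](O)[C@H](O)[C@H]2O)s1`) likewise gives "not active" (no number reported) in the same test. Within the data shown here, the only number so far belongs to compound 1 (`CCCCCCCCCCCC(=O)Nc1nnc(S[C@@H]2O[C@H](COC(C)=O)[C@H](OC(C)=O)[C@H](OC(C)=O)[C@H]2OC(C)=O)s1`), which gives 16900 nM as the sole measured value. Compound 4 (`CCCCCCCCCCCCCC(=O)Nc1nnc(S[C@@H]2O[C@H](CO)[C@H](O)[C@H](O)[C@H]2O)s1`) remains unmeasured. The structural change (hexyl in place of dec-1-en-1-yl on a saturated chain carbon, seven bonds along the chain from a carbonyl carbon) sits on a saturated chain carbon, seven bonds along the chain from a carbonyl carbon. Among the measured compounds shown here, no measured step sets a size, so no defined step or direction is expected in this assay and compound 4 will probably stay without a number, as compound 3 did with "not active" (no number reported) in that test. For compound 4 the half-maximal inhibitory concentration is estimated at 50000 nM with an expected range of 15000 nM to 150000 nM if a number is reported at all.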

Compound 4, half-maximal inhibitory concentration: "not active" (no number reported)
Compound 4 has no reported number here; the estimate stays without a comparison.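

In this assay compound 3 and compound 4 both carry no number, and no step can be read between them. No evidence bears on this result. The compounds shown leave open whether exchanging dec-1-en-1-yl for hexyl changes cytotoxicity at all.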